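Ester in place of amide on the shared core carbonyl

The source may hold more compounds than are shown below. What is called first, only, known or untested is meant among the compounds shown, and "the series" means these compounds.

compound 1 `CC[C@@H](C)[C@H](NC(=O)c1ccc(C(CC)(CC)c2ccc(OCC(=O)C(C)(C)C)c(C)c2)n1CC)C(=O)OC` — 590 nM
compound 2 `CCOC(=O)CN(C)C(=O)c1ccc(C(CC)(CC)c2ccc(OCC(=O)C(C)(C)C)c(C)c2)n1CC` — limit, > 50000 nM
compound 3 `CCn1c(C(=O)N(C)CCC#N)ccc1C(CC)(CC)c1ccc(OCC(=O)C(C)(C)C)c(C)c1` — 9800 nM

In an assay on HL-60 cells for agonist activity at vitamin D3 receptor (Homo sapiens), read by microscopy, with a stated time of 96 h (a lower number here means that less compound is needed, a higher number that more compound is needed for the effect), compound 3 gives 9800 nM, the higher of the two numbers shown, while compound 1 gives 590 nM. For compound 2 the result > 50000 nM is a limit of this assay and not a number (the limit of > 50000 nM in this assay, at which 1 of the 3 values shown sits). Compound 4 `C#CCCOC(=O)c1ccc(C(CC)(CC)c2ccc(OCC(=O)C(C)(C)C)c(C)c2)n1CC` is compound 3 with (but-3-yn-1-yl)oxy in place of (2-cyanoethyl)(methyl)amino on a carbonyl carbon. For the measured compounds named here, the measured steps that touch this position are a 17-fold higher number from compound 1 to compound 3 (1.22 log units; beyond the scatter) and an at least 5.1-fold lower number from compound 2 to compound 3 (0.70 log units; beyond the scatter); both exchange one amino substituent for another, and no measured step replaces the amide nitrogen by an oxygen, so the direction for compound 4 is open. The step from compound 3 to compound 4 is expected to be small, a 1.6-fold lower number from compound 3 to compound 4 (0.21 log units; within the scatter). Compound 4 is estimated at 6000 nM, with a range from 1000 nM to 40000 nM.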

Compound 4, half-maximal effective concentration: 28800 nM
Compound 4: the middle estimate sits 4.8-fold (0.68 log units) below what was measured, and the stated range covers the measured number.
By their numbers in this assay, from the lowest: compound 1; then compound 3; then compound 4. At a limit, above all of these: compound 2.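

Putting an ester on the carbonyl carbon, in place of the amides so far, gives a 2.9-fold higher number from compound 3 to compound 4 (0.47 log units; beyond the scatter), so (but-3-yn-1-yl)oxy does not stand in for (2-cyanoethyl)(methyl)amino at this position. Against the (1-(methoxycarbonyl)-2-methylbutyl)amino group the gap is wider, with a 49-fold higher number from compound 1 to compound 4 (1.69 log units; beyond the scatter). The step of an at least 1.7-fold lower number from compound 2 to compound 4 (0.23 log units; that floor lies within the scatter) gives only a floor, as the value of compound 2 is a limit: the limit of > 50000 nM in this assay, at which 1 of the 4 values shown sits.

From the compounds shown here alone, in compound 4 the oxygen and the chain change together, so the share of each stays open. A methyl ester, a carboxylic acid or an amide bearing a but-3-yn-1-yl chain on this carbonyl would separate them.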